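This account rests on a few compounds, and the source may have more. Where it says the series, first, only, none or still open, it means among the compounds named here.

Of the compounds shown here, three built on one shared core have been measured in a functional assay on HCC1937 cells (Homo sapiens) for antiproliferative activity, read by CCK-8 assay, with a stated time of 72 h; a lower number here means a stronger inhibitor, a higher number a weaker inhibitor. Compound 1 `COc1ccc(C(=O)Nc2cccc(-c3oc4cc(-c5ccc(F)cc5)ccc4c(=O)c3O)c2)cc1` gives 5490 nM, the lowest of the three numbers. Compound 2 `Cc1ccccc1C(=O)Nc1cccc(-c2oc3cc(-c4ccc(F)cc4)ccc3c(=O)c2O)c1` gives 9900 nM, and compound 3 `O=C(Nc1cccc(-c2oc3cc(-c4ccc(F)cc4)ccc3c(=O)c2O)c1)c1ccc(-c2ccccc2)cc1` gives 44100 nM. The step of a 1.8-fold higher number from compound 1 to compound 2 (0.26 log units; within the scatter) stays within the scatter, so compounds 1 and 2 cannot be ordered, whereas an 8.0-fold higher number from compound 1 to compound 3 (0.90 log units; beyond the scatter) and a 4.5-fold higher number from compound 2 to compound 3 (0.65 log units; beyond the scatter) both lie beyond it.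

Compound 4 `CCCc1ccc(C(=O)Nc2cccc(-c3oc4cc(-c5ccc(F)cc5)ccc4c(=O)c3O)c2)cc1` has not yet been measured in this assay. It differs from compound 1 in one place: propyl in place of methoxy on an aromatic carbon. The measured step that bears on this change is an 8.0-fold higher number from compound 1 to compound 3 (0.90 log units; beyond the scatter), in which a phenyl entered on that same aromatic carbon in place of the methoxy and the number rose modestly. Propyl is a shorter replacement than phenyl, and no measured compound carries an alkyl chain at this position, so the size of the expected rise is uncertain. Compound 4 is expected to show a step of a 2.2-fold higher number from compound 1 to compound 4 (0.34 log units; beyond the scatter), a rise smaller than the one seen for an 8.0-fold higher number from compound 1 to compound 3 (0.90 log units; beyond the scatter). Compound 4 is estimated to give 12000 nM in this assay, within a range from 5000 nM to 30000 nM.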

Compound 4, half-maximal inhibitory concentration: 15400 nM
Beside the measured number, compound 4's estimate is 1.3-fold (0.11 log units) below it; the range from low to high includes it.
By their numbers in this assay, from the lowest: compounds 1, 2 and 4 (each within the scatter of the next, the first and the last beyond it); then compound 3.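

In this assay, a 2.8-fold higher number from compound 1 to compound 4 (0.45 log units; beyond the scatter) shows that the rise seen on replacing methoxy on this aromatic carbon is not confined to the phenyl of compound 3, as an open-chain propyl with no ring also carries the number beyond the scatter. The propyl and phenyl groups are still not interchangeable here: a 2.9-fold lower number from compound 3 to compound 4 (0.46 log units; beyond the scatter) is also beyond the scatter, so along this single position compound 4 sits between compound 1 and compound 3. Set against the 2-methylphenyl group of compound 2, the 4-propylphenyl group gives a 1.6-fold higher number from compound 2 to compound 4 (0.19 log units; within the scatter), which lies within the scatter, so compound 2 and compound 4 cannot be ordered.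

No evidence is available to explain any of these steps. As far as these compounds go, it remains open whether an ethyl group, a longer chain such as pentyl, or an amine, a hydroxyl or a carboxylic acid on this aromatic carbon would leave the number near that of compound 1 or carry it further up.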